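The source may hold more compounds than are shown below. What is called first, only, known or untested is meant among the compounds shown, and "the series" means these compounds.

Working notes on the series. Among the compounds with values here, compound 1 `Cn1sc2cc(OCc3cccc(-c4ccc(Cl)c(C(=O)O)c4)c3)ccc2c1=O` and compound 2 `O=C(O)c1cc(-c2cccc(COc3ccc4c(=O)n(CC5CC5)sc4c3)c2)ccc1Cl` are the measured pair: in an assay on HEK293 cells for positive allosteric modulation of metabotropic glutamate receptor 2 (Rattus norvegicus), read by thallium flux (a lower number here means a smaller maximal response, a higher number a larger maximal response), compound 1 gives 74.7% and compound 2 gives 38.4%, and the one step in hand, a number 36.3 percentage points lower from compound 1 to compound 2 (beyond the scatter), concerns only the group on the saturated chain carbon bound to the aromatic nitrogen. Compound 3 `O=C1c2ccc(OCc3cccc(-c4ccccc4)c3)cc2CN1C1CCCC1` stands nowhere on these numbers; in this assay compound 3 has "not determined" (no result reported). Compound 4 `Cc1ccc(C(=O)O)cc1-c1cccc(COc2ccc3c(c2)CN(C2CCCC2)C3=O)c1` differs from compound 3 in one place: 5-carboxy-2-methylphenyl in place of phenyl on an aromatic carbon. Within the data shown here, no measured step concerns this change, and the step between compound 1 and compound 2 touches a different part of the molecule, so neither direction nor size in this assay can be read from the data. The response of compound 4 is estimated at 60%, expected within 30% to 90%.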

Compound 4, largest response reached (reported as percent of maximum), in percent of the reference or control that the assay uses: 80.8%
Estimate against measurement, compound 4: 20.8 percentage points below; low and high end bracket the measured number.
By their numbers in this assay, from the lowest: compound 2; then compounds 1 and 4 (each within the scatter of the next).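

Within the data shown here, compound 3, with "not determined" (no result reported) in this assay, gives no new step to compound 4. No available evidence bears on this result. On these data alone, what 5-carboxy-2-methylphenyl in place of phenyl does to the maximal response stays open.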